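The source may hold more compounds than are shown below. What is called first, only, known or untested is meant among the compounds shown, and "the series" means these compounds.

Working notes on the series

Of the compounds shown here, two have numbers so far. Compound 1 `C/N=C(/NC#N)NCCCn1nc(-c2ccccc2)ccc1=O` and compound 2 `O=c1ccc(-c2ccccc2)nn1CCCCNC(=S)Nc1ccc(Cl)cc1` share a core and were both run in a functional assay on the whole organism with Rattus norvegicus as the target, at a dose of 100 mg/kg; a higher number here means more inhibition at the dose given (going by the name of the read-out), a lower number less inhibition. Compound 1 gives 40.5%, and compound 2 gives 43.2%. Compound 2 thus carries the higher of the two figures, but the gap to compound 1 lies within the scatter of repeated measurements, so the two are not told apart. Among the measured compounds shown here, the structures of compound 1 and compound 2 differ in more than one place, and no single-point step between measured compounds is available.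

Compound 3 `O=c1ccc(-c2ccccc2)nn1CCCCNC(=S)NC1CCCCC1` has not been measured. It is reached from compound 2 by the change (cyclohexyl in place of 4-chlorophenyl on an amide-type nitrogen). For the measured compounds named here, nothing among the measured compounds speaks to this change, so no step beyond the scatter is expected in this assay in either direction. The expected step is a number 5.2 percentage points lower from compound 2 to compound 3 (within the scatter), and for compound 3 the expected value is 38%, within a range from 18% to 58%, with the wide range reflecting the absence of any measured step to rest on.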

Compound 3, a percentage reported as inhibition, in the whole organism at one dose (the size of the read-out at that dose, not a potency): 18.1%
Compound 3: the middle estimate sits 19.9 percentage points above what was measured; the measured number falls inside the stated range.
By their numbers in this assay, from the lowest: compound 3; then compounds 1 and 2 (each within the scatter of the next).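

In this assay, among the compounds shown here, the change to cyclohexyl in place of 4-chlorophenyl on an amide-type nitrogen gives a number 25.1 percentage points lower from compound 2 to compound 3 (beyond the scatter), the first single-point step and the first sign that the number responds to the group at this position. The two groups are close in what can be counted: each is one six-membered ring of carbon with no hydrogen-bond donors, no hydrogen-bond acceptors and no net charge, yet the step lies beyond the scatter, so replacing the aromatic chlorine-bearing ring with a non-aromatic ring of carbon only is not neutral here. No measurement on hand gives a reason for this step.

The step changes two things at once, the aromatic ring and the chlorine, and the compounds shown cannot assign it to either one; an unsubstituted phenyl on the same nitrogen would separate them. Also open, from the compounds shown here alone, is how a benzyl, with one more carbon between the nitrogen and the ring, or a 4-fluorophenyl would stand against compound 2 and compound 3.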